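The compounds below may be only part of what the source reports. "The series", "measured", "known", "first", "only" and "open" are said of these compounds alone.

Measured in an in vitro ADME assay on microsomes from liver (Homo sapiens) for pharmacokinetics, read by LC-MS, with a stated time of 10 min, tested at 1 uM; on this read-out lower numbers stand for slow clearance and higher numbers for fast clearance:
- compound 1 `CN1C[C@H](C(=O)Nc2ccc(F)c(Cl)c2)[C@@H](c2ccc(/C=C/C(=O)Nc3ccccc3N)cc2)C1`: 15 mL/min/kg
- compound 2 `CN1C[C@H](C(=O)Nc2ccc(Cl)cc2F)[C@@H](c2ccc(/C=C/C(=O)Nc3ccccc3N)cc2)C1`: 11 mL/min/kg

Compound 2, at 11 mL/min/kg, stands within the scatter of compound 1. Compound 3 `CC(C)NC(=O)[C@H]1CN(C)C[C@@H]1c1ccc(/C=C/C(=O)Nc2ccccc2N)cc1` is still unmeasured and carries isopropyl in place of 4-chloro-2-fluorophenyl on an amide-type nitrogen. Within the data shown here, the only measured step at this place, a 1.4-fold lower number from compound 1 to compound 2 (0.13 log units; within the scatter), lies within the scatter and keeps an aromatic ring there, so no measured step shows the loss of that ring, and it gives no direction. In this assay the expected change is a 1.1-fold lower number from compound 2 to compound 3 (0.04 log units; within the scatter), not beyond the scatter. For compound 3 the estimated clearance is 10 mL/min/kg, with an expected range of 4 mL/min/kg to 24 mL/min/kg.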

Compound 3, clearance: 8 mL/min/kg
Compound 3: the middle estimate sits 1.3-fold (0.10 log units) above what was measured; the measured number falls inside the stated range.
By their numbers in this assay, from the lowest: compounds 3, 2 and 1 (each within the scatter of the next).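

In this assay, replacing an aromatic ring on the amide-type nitrogen with isopropyl, a group with no ring, stays within the scatter for both halogenated phenyl groups: a 1.4-fold lower number from compound 2 to compound 3 (0.14 log units; within the scatter), and a 1.9-fold lower number from compound 1 to compound 3 (0.27 log units; within the scatter). Across these three compounds, the aromatic ring at this place is therefore not required for a clearance number in this range. Nothing available explains this result.

Still open, going by these compounds, is whether a longer chain, an amine or a carboxylic acid on this nitrogen would also stay within the scatter.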